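Acetyl for dimethylamino on the distal phenyl of compound 1

The compounds below may be only part of what the source reports. "The series", "measured", "known", "first", "only" and "open" are said of these compounds alone.

For the measured compounds named here, compound 1 `COc1cc(C)cc(-c2c(-c3ccnc(-c4ccc(N(C)C)cc4)c3)cnn2CC#N)c1` is the weakest of the three measured members in a functional assay on HCT-116 cells (Homo sapiens) for cytotoxicity, read by sulforhodamine B assay, with a stated time of 48 h, tested at 10 uM (a higher number here means a weaker effect of the compound at the concentration tested, a lower number a stronger effect), giving -27%. Compound 2 `COc1cc(C)cc(-c2nn(CC#N)cc2-c2ccnc(-c3ccc(N(C)C)cc3)c2)c1` gives -44% and compound 3 `Cc1cc(O)cc(-c2nn(CC#N)cc2-c2ccnc(-c3ccc(N(C)C)cc3)c2)c1` gives -81%. Going by the values given here, the one single-point step on record, a number 37 percentage points lower from compound 2 to compound 3 (beyond the scatter), concerns the oxygen substituent on the methyl-bearing ring and does not touch the group exchanged here.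

Compound 4 `COc1cc(C)cc(-c2c(-c3ccnc(-c4ccc(C(C)=O)cc4)c3)cnn2CC#N)c1` differs from compound 1 as follows: acetyl in place of dimethylamino on an aromatic carbon. Among the compounds with values here, no measured pair probes this position, so there is no basis for expecting a step beyond the scatter in either direction in this assay. The number for compound 4 is therefore estimated close to that of compound 1, with a step of no change at the digits printed from compound 1 to compound 4 (within the scatter), giving an expected -27% within a range from -60% to 5%.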

Compound 4, a percentage reported as activity, at one concentration (the size of the read-out at that concentration, not a potency): -17%
Beside the measured number, compound 4's estimate is 10 percentage points below it, within the range that was stated.
By their numbers in this assay, from the lowest: compound 3; then compound 2; then compounds 1 and 4 (each within the scatter of the next).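

In this assay this position now has its first reading, and acetyl in place of dimethylamino gives a number 10 percentage points higher from compound 1 to compound 4 (within the scatter) with no separation between the two compounds. On the core of compound 1, the dimethylamino nitrogen is therefore not needed to keep the read-out at this level. No measurement on hand bears on the reason for this result.

From the compounds shown here alone, whether a primary amine, a carboxylic acid or a longer chain at this place would read alike remains open. So does the outcome of the same exchange on the core of compound 2 or compound 3.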